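From cyclopropyl to cyclobutyl on a sulfonyl sulfur

The source may report more compounds than this note shows. Statements on the series, on what has been measured and on what is new or still open speak of the compounds shown alone.

Measured so far in an ADME assay on MDCKII-LE cells (Canis lupus familiaris) for permeability; a higher number here means that the compound crosses the layer faster, a lower number that the compound crosses the layer more slowly 
- compound 1 `O=C(O)c1ccc(NC(=O)[C@H](CC2CCCCC2)n2cnc(S(=O)(=O)C3CCC3)c2)nc1` gives 0.3 10^-6 cm/s 
- compound 2 `O=C(O)c1ccc(NC(=O)[C@H](CC2CCOCC2)n2cnc(S(=O)(=O)C3CC3)c2)nc1` gives 0.9 10^-6 cm/s 

Of these two, compound 2 has the higher number, and the gap to compound 1 lies beyond the usual scatter of repeated measurements. The next compound to be tested is compound 3 `O=C(O)c1ccc(NC(=O)[C@H](CC2CCOCC2)n2cnc(S(=O)(=O)C3CCC3)c2)nc1`. It differs from compound 2 in one place, on a sulfonyl sulfur whose other neighbour is an aromatic carbon, where cyclobutyl takes the place of cyclopropyl: cyclobutyl in place of cyclopropyl on a sulfonyl sulfur.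

For the measured compounds named here, the two measured compounds do not differ in just one place, so no measured step shows what this change does in this assay. The swap is a small one between two carbon-only rings, so the starting point is compound 2 at 0.9 10^-6 cm/s. Compound 1, which also carries cyclobutyl on a sulfonyl sulfur, gives 0.3 10^-6 cm/s, which suggests a slight downward lean, although a single compound settles little. The expected change is a 1.3-fold lower number from compound 2 to compound 3 (0.11 log units; within the scatter), which would stay within the scatter. For compound 3 the estimated value is 0.7 10^-6 cm/s, with an expected range from 0.35 10^-6 cm/s to 1.4 10^-6 cm/s.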

Compound 3, apparent permeability in the MDCKII-LE assay: 0.9 10^-6 cm/s
Compound 3: the middle estimate sits 1.3-fold (0.11 log units) below what was measured; the measured number falls inside the stated range.
By their numbers in the MDCKII-LE assay, from the lowest: compound 1; then compounds 2 and 3 (each within the scatter of the next).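

In the MDCKII-LE assay compound 2 gives 0.9 10^-6 cm/s and compound 3 gives 0.9 10^-6 cm/s and the swap on the sulfonyl sulfur gives (no change at the digits printed from compound 2 to compound 3 (within the scatter)), so for this pair, with oxan-4-yl held in place, one more ring carbon on the sulfonyl group does not move the read-out beyond the scatter. In a physicochemical assay for lipophilicity, at pH 7.4 (on this read-out lower numbers stand for lower lipophilicity and higher numbers for higher lipophilicity), compound 2 gives -1.85 and compound 3 gives -1.55 and the same swap gives (a number 0.30 log units higher from compound 2 to compound 3 (within the scatter)), which also stays within the scatter. Compound 3 also provides the first comparison at the other site: with cyclobutyl held fixed on the sulfonyl sulfur, oxan-4-yl in place of cyclohexyl on the saturated chain carbon gives, in the MDCKII-LE assay, (a 3.0-fold higher number from compound 1 to compound 3 (0.48 log units; beyond the scatter)), a modest step beyond the scatter and the only such step among these compounds.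

No measurement here explains why either site behaves as it does. The compounds shown also leave open whether the sulfonyl sulfur stays as forgiving with a cyclopentyl ring, a longer chain such as n-butyl, or an amine in place of these small carbon rings, and whether the result for cyclobutyl and cyclopropyl would repeat with cyclohexyl rather than oxan-4-yl on the chain.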